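The source may report more compounds than this note shows. Statements on the series, on what has been measured and on what is new or still open speak of the compounds shown alone.

Compound 1 `Cc1c(C(=O)N/N=C\c2ccc(C(F)(F)F)cc2)oc2cccc(O)c12`: in a functional assay on PC-3 cells (Homo sapiens) for inhibition (on this read-out lower numbers stand for stronger inhibition and higher numbers for weaker inhibition), compound 1 gives >= 40000 nM.
Compound 2 `Cc1c(C(=O)N/N=C\c2cccc(F)c2)oc2cccc(O)c12`: in this assay compound 2 gives >= 40000 nM.
Compound 3 `Cc1c(C(=O)N/N=C\c2ccc(F)cc2)oc2cccc(O)c12`: in this assay compound 3 gives >= 40000 nM.

Each of these three values is a limit of the assay, not a number: the limit of >= 40000 nM in this assay, at which 3 of the 3 values shown sit. Compound 2 therefore stands at that limit, and nothing places it above or below the other two. The two single-change steps measured so far, a step that the two limits leave unreadable from compound 1 to compound 3 and a step that the two limits leave unreadable from compound 2 to compound 3, run between limits and neither has a readable size.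

Compound 4 `COc1ccccc1/C=N\NC(=O)c1oc2cccc(O)c2c1C` differs from compound 2 in one place: 2-methoxyphenyl in place of 3-fluorophenyl on a carbon with a double bond to nitrogen. Among the measured compounds shown here, the step that bears on this change is the one from compound 2 to compound 3, which swaps the ring on the same carbon, but its size cannot be read. No step shown here gives any direction or size beyond the scatter, so no shift is expected.

Compound 4 is expected to give about 40000 nM, with a range from 10000 nM to 100000 nM. The step from compound 2 to compound 4 is expected to be a number no higher from compound 2 to compound 4 (the limit leaves the size open).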

Compound 4, half-maximal inhibitory concentration: 32700 nM
Beside the measured number, compound 4's estimate is 1.2-fold (0.09 log units) above it, within the range that was stated.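

Of the compounds shown, only compound 4 gives a true number in this assay, while the others remain at a limit: the limit of >= 40000 nM in this assay, at which 3 of the 4 values shown sit.

Placing 2-methoxyphenyl on the carbon with a double bond to nitrogen brings an at least 1.2-fold lower number from compound 2 to compound 4 (0.08 log units; that floor lies within the scatter), and likewise an at least 1.2-fold lower number from compound 3 to compound 4 (0.08 log units; that floor lies within the scatter). Each of these is only a floor, so the real gap could be larger, but as printed neither goes beyond the scatter, and this change cannot yet be called a gain, while the steps between the limit compounds still cannot be read.

The compounds shown leave open whether a different group on this ring, such as an amine or a hydroxy group, would also give a number. Also open, going by these compounds, is what a carboxylic acid or a longer chain at this same place would do.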